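Chloro to fluoro on the phenyl ring: expected lipophilicity

The compounds below may be only part of what the source reports. "The series", "measured", "known", "first", "only" and "open" are said of these compounds alone.

Compound 2 `Cc1c(CN2CCCC2)cc(-c2ccc(Cl)cc2)n1Nc1ccnc2cc(Cl)ccc12` stands highest of the two numbers measured in a physicochemical assay for lipophilicity, at pH 7.4; a higher number here means a more lipophilic compound, a lower number a more polar compound; in this assay compound 2 gives 4.06. Its nearest neighbour is compound 1 `Cc1c(CN2CCCC2)cc(-c2ccccc2)n1Nc1ccnc2cc(Cl)ccc12`, which in this assay gives 3.28. Going by the values given here, the one step measured between these two, a number 0.78 log units higher from compound 1 to compound 2 (beyond the scatter), is the only change so far on the phenyl ring of the shared core: chloro in place of hydrogen on an aromatic carbon.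

Compound 3 `Cc1c(CN2CCCC2)cc(-c2ccc(F)cc2)n1Nc1ccnc2cc(Cl)ccc12` differs from compound 2 by fluoro in place of chloro on an aromatic carbon; the change sits on an aromatic carbon of a six-membered aromatic ring of carbon only, para to a large group. The step from compound 1 to compound 2 bears on it, as it measures what chloro adds at this place relative to hydrogen; nothing measured here tells what fluoro adds at the same place. Fluoro is expected to land between hydrogen and chloro, so a downward step in this assay beyond the scatter is expected for compound 3, smaller than the upward step from compound 1 to compound 2. The step from compound 2 to compound 3 is estimated at a number 0.61 log units lower from compound 2 to compound 3 (beyond the scatter). Compound 3 is expected to give 3.45, with a range from 3.15 to 3.8.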

Compound 3, distribution coefficient: 3.45
Compound 3: the middle estimate sits on the measured number at the digits printed; the measured number falls inside the stated range.
By their numbers in this assay, from the lowest: compounds 1 and 3 (each within the scatter of the next); then compound 2.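

At this place on the phenyl ring, this assay separates the two halogens, with a number 0.61 log units lower from compound 2 to compound 3 (beyond the scatter) as the step for fluoro in place of chloro. Going by these compounds alone, the first reading for fluoro against hydrogen at the same carbon is a number 0.17 log units higher from compound 1 to compound 3 (within the scatter), so compound 1 and compound 3 cannot be told apart in this assay, and among hydrogen, fluoro and chloro only chloro stands apart at this place, a finding limited to these three compounds. Nothing on hand accounts for the difference between the two halogens.

Open, from the compounds shown here alone, is how other groups at this same carbon would read against these three, for example bromo, methoxy, trifluoromethyl, nitrile, an amine or a carboxylic acid, and whether any of them would stand as far from hydrogen as chloro does. Also open, going by these compounds, is whether the gap between the 4-chlorophenyl and 4-fluorophenyl compounds keeps its size when the shared core carries a change elsewhere, such as a longer chain in place of the methyl group.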